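Chloro on the benzyl ring of a thio-substituted core

The source may report more compounds than this note shows. Statements on the series, on what has been measured and on what is new or still open speak of the compounds shown alone.

Measured compounds:
compound 1, `COc1ccc(C2N=C(SCc3ccccc3)NC(C)=C2C(=O)Nc2ccc(F)cc2)cc1OC`, in a functional assay on the whole organism (artery, strain albino) with Rattus norvegicus as the target, with a stated time of 600 min, at a dose of 10 mg/kg by the oral route (on this read-out higher numbers stand for more inhibition at the one dose given (going by the name of the read-out) and lower numbers for less inhibition), gives 3.1%;
compound 2, `CC1=C(C(=O)Nc2ccc(F)cc2)C(c2ccc([N+](=O)[O-])cc2)N=C(SCc2ccccc2)N1`, in this assay gives 32.3%.

Compound 2 stands highest of the two numbers shown; its nearest neighbour is compound 1, and the single measured step, a number 29.2 percentage points higher from compound 1 to compound 2 (beyond the scatter), concerns the aryl group on the saturated ring carbon, not the benzylsulfanyl side.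

Compound 3, `CC1=C(C(=O)Nc2ccc(F)cc2)C(c2ccc([N+](=O)[O-])cc2)N=C(SCc2cccc(Cl)c2)N1`, differs from compound 2 by chloro in place of hydrogen on an aromatic carbon, a change on the benzyl ring of the sulfanyl group: phenyl to 3-chlorophenyl, benzyl to 3-chlorobenzyl. For the measured compounds named here, no measured step touches this part of the shared core, so the one step known, from the aryl group on the saturated carbon, does not bear on it. With nothing to point either way, the step is expected to be none beyond the scatter, and the estimated step of a number 0.3 percentage points lower from compound 2 to compound 3 (within the scatter) reflects that. Compound 3 is therefore expected to give 32% in this assay. The range of the estimate for compound 3 runs from 12% to 52%; it is wide, as nothing measured informs this position.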

Compound 3, a percentage reported as inhibition, in the whole organism at one dose (the size of the read-out at that dose, not a potency): 16.4%
Compound 3: the middle estimate sits 15.6 percentage points above what was measured, within the range that was stated.
By their numbers in this assay, from the lowest: compound 1; then compound 3; then compound 2.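

For the compounds shown here, the benzyl ring of the sulfanyl group, which no earlier step had touched, turns out not to be a silent part of the molecule: in this assay a single chloro in place of hydrogen on an aromatic carbon, meta to a large group, comes with a number 15.9 percentage points lower from compound 2 to compound 3 (beyond the scatter) as the read-out at the one oral dose. So the aryl group on the saturated ring carbon is not the only place where a small change moves this number, and here one added heavy atom is enough to take it beyond the scatter, in the direction of less inhibition. Nothing available explains this fall, and the data give no reason for it.

The compounds shown leave open whether the fall belongs to chloro itself or would also follow other groups at this place on the benzyl ring, such as methoxy, methyl or an amine. They also leave open whether the same chloro would shift the number in the same direction on the core of compound 1, which carries the 3,4-dimethoxyphenyl group in place of the 4-nitrophenyl group.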